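Aryl Group Exchange on a Succinimide Piperazine Amide

A few compounds are considered here, and "the series" means these few. Any claim that something is new, unique, unknown or untested is made for them only; others in the source may bear on it.

Measured compounds:
compound 1, `COc1cccc(N2CCN(C(=O)C(C)N3C(=O)CCC3=O)CC2)c1`: 0%
compound 2, `CCC(C(=O)N1CCN(c2ccccc2Cl)CC1)N1C(=O)CCC1=O`: 50%

Of the compounds shown here, two have been measured in a functional assay on the whole organism (strain Swiss) with Mus musculus as the target, in the maximal electroshock model, with a stated time of 1 h, at a dose of 300 mg/kg by the intraperitoneal route; on this read-out higher numbers stand for a stronger effect at the one dose given and lower numbers for a weaker effect. Compound 1 `COc1cccc(N2CCN(C(=O)C(C)N3C(=O)CCC3=O)CC2)c1` gives 0%. Compound 2 `CCC(C(=O)N1CCN(c2ccccc2Cl)CC1)N1C(=O)CCC1=O` gives 50%. Of the two numbers, compound 2 stands highest; its nearest neighbour is compound 1, a number lower by a gap that lies beyond the usual scatter of this kind of measurement.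

Compound 3 `CCC(C(=O)N1CCN(c2cccc(OC)c2)CC1)N1C(=O)CCC1=O` has not yet been measured. It differs from compound 2 in one place: 3-methoxyphenyl in place of 2-chlorophenyl on an amine nitrogen in a ring. Going by the values given here, no two measured compounds differ in just this one place, so the size of this step cannot be read from a measured pair. The same 3-methoxyphenyl group on the amine nitrogen in a ring is carried by compound 1, which gave 0%, while compound 2 carries 2-chlorophenyl and gave the higher number. The step from compound 2 to compound 3 is therefore expected to be downward, a number 35 percentage points lower from compound 2 to compound 3 (beyond the scatter), beyond the scatter. Compound 3 is estimated to give about 15%, in a range from 0% to 45%.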

Compound 3, a percentage reported as activity, at one dose (the size of the read-out at that dose, not a potency): 0%
Estimate against measurement, compound 3: 15 percentage points above; measured number inside the range.
By their numbers in this assay, from the lowest: compounds 1 and 3 (each within the scatter of the next); then compound 2.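

In this assay, going by these compounds alone, the exchange of 2-chlorophenyl for 3-methoxyphenyl on an amine nitrogen in a ring now has a measured size of its own (a number 50 percentage points lower from compound 2 to compound 3 (beyond the scatter)), which no earlier pair could supply. This is a large step, so at this position and at this one dose, the choice of aryl group separates the two compounds clearly. Within the data shown here, the chain can also be read for the first time: with 3-methoxyphenyl held fixed, methyl in place of hydrogen on a saturated chain carbon gives a step within the scatter (no change at the digits printed from compound 1 to compound 3 (within the scatter)), so this pair shows no difference from that chain change. Nothing measured here bears on why the aryl exchange has this size.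

The compounds shown leave open whether the step belongs to the chlorine, the methoxy group or the place each holds on the phenyl ring, and an unsubstituted phenyl, a 3-chlorophenyl or a 2-methoxyphenyl group on the same nitrogen would begin to separate these. They also leave open whether the same chain change would still give so small a step with 2-chlorophenyl on that nitrogen, or what a longer chain would give.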